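Extending the aryl chain on the cyclohexyl analogue

This account rests on a few compounds, and the source may have more. Where it says the series, first, only, none or still open, it means among the compounds named here.

The three measured compounds share one core and differ only in the group on an aromatic nitrogen. Compound 1 `CCCCc1ccc(-c2c(C)[nH]c(=O)n2CCCC)cc1` gives 12000 nM in a functional assay on brain (Rattus norvegicus, strain Wistar) for inhibition; on this read-out lower numbers stand for stronger inhibition and higher numbers for weaker inhibition. Compound 2 `CCCCc1ccc(-c2c(C)[nH]c(=O)n2C2CCCCC2)cc1` gives 27100 nM, and compound 3 `CCCCc1ccc(-c2c(C)[nH]c(=O)n2-c2ccccc2)cc1` gives 16600 nM. On these numbers compound 2 carries the highest value: the step of a 2.3-fold higher number from compound 1 to compound 2 (0.35 log units; beyond the scatter) lies beyond the scatter, whereas the step of a 1.6-fold lower number from compound 2 to compound 3 (0.21 log units; within the scatter) does not, so compound 2 and compound 3 cannot be ordered against each other.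

Compound 4 `CCCCCCCCc1ccc(-c2c(C)[nH]c(=O)n2C2CCCCC2)cc1` keeps the cyclohexyl group of compound 2 and changes the chain on the aromatic ring: butyl in place of hydrogen on a saturated chain carbon, four bonds along the chain from an aromatic carbon. Among the compounds with values here, none of the measured steps touches this chain; the steps of a 2.3-fold higher number from compound 1 to compound 2 (0.35 log units; beyond the scatter) and a 1.4-fold higher number from compound 1 to compound 3 (0.14 log units; within the scatter) concern only the nitrogen substituent. Nothing in the measurements therefore points to a change beyond the scatter in either direction. Compound 4 is accordingly estimated at 25000 nM, with a range of 8000 nM to 80000 nM, which amounts to an expected step of a 1.1-fold lower number from compound 2 to compound 4 (0.04 log units; within the scatter).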

Compound 4, half-maximal inhibitory concentration: 10300 nM
The estimate for compound 4 lay 2.4-fold (0.39 log units) above the measured number; measured number inside the range.
By their numbers in this assay, from the lowest: compounds 4, 1, 3 and 2 (each within the scatter of the next, the first and the last beyond it).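

Within the data shown here, until now every step concerned only the group on the aromatic nitrogen, so compound 4 gives the first reading on the chain on the aromatic ring. In this assay, butyl in place of hydrogen, four bonds along the chain from an aromatic carbon, gives a 2.6-fold lower number from compound 2 to compound 4 (0.42 log units; beyond the scatter) and so moves the number beyond the scatter, although the step is modest. No available evidence accounts for this step. The compounds shown leave open whether a longer chain, or a chain ending in an amine or a carboxylic acid, would move the number further. They also leave open whether the same butyl extension gives a step of like size when butyl or phenyl, rather than cyclohexyl, sits on the aromatic nitrogen.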